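The source may report more compounds than this note shows. Statements on the series, on what has been measured and on what is new or still open speak of the compounds shown alone.

Three compounds were measured in a functional assay on CCRF-CEM cells (Homo sapiens), with a stated time of 72 h; on this read-out higher numbers stand for weaker inhibition and lower numbers for stronger inhibition:

Compound 1 `Cc1ccc(NC(=S)N/N=C2\C(=O)Nc3ccc(F)cc32)cc1`: 4800 nM
Compound 2 `O=C1Nc2ccc(F)cc2/C1=N/NC(=S)Nc1ccc(Cl)cc1`: 25000 nM
Compound 3 `Cc1ccc(CN2C(=O)/C(=N\NC(=S)Nc3ccc(Cl)cc3)c3cc(Cl)ccc32)cc1`: 18000 nM

Compound 2 differs from compound 1 by chloro in place of methyl on an aromatic carbon, and this gave a 5.2-fold higher number from compound 1 to compound 2 (0.72 log units; beyond the scatter). Compound 3 stands on a different core; the difference between the two cores is not broken down here. Against compound 2, compound 3 lies within the scatter, while against compound 1 it reads beyond it.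

Compound 4 `O=C1/C(=N\NC(=S)Nc2ccc(Cl)cc2)c2cc(Cl)ccc2N1Cc1ccc(Cl)cc1` is still to be measured. It differs from compound 3 by chloro in place of methyl on an aromatic carbon, the same kind of change as from compound 1 to compound 2, though here, read one bond further out, it is the 4-methylbenzyl that becomes 4-chlorobenzyl rather than the 4-methylphenyl on the thiourea. On that account the earlier step is a guide only in direction: the number is expected to rise by less, estimated as a 1.5-fold higher number from compound 3 to compound 4 (0.18 log units; within the scatter), because the move measured as a 5.2-fold higher number from compound 1 to compound 2 (0.72 log units; beyond the scatter) sat at another part of the molecule. Compound 4 is therefore estimated at 27000 nM, with a likely range from 10000 nM to 70000 nM.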

Compound 4, half-maximal inhibitory concentration: 68000 nM
Compound 4: middle estimate off by 2.5-fold (0.40 log units), on the low side, within the range that was stated.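

In this assay, chloro in place of methyl on an aromatic carbon gave a higher number on both cores, with the new step reading a 3.8-fold higher number from compound 3 to compound 4 (0.58 log units; beyond the scatter) in the 4-methylbenzyl to 4-chlorobenzyl case. Set beside the earlier step, the two sizes cannot be told apart: the same change on two cores in this assay, a 5.2-fold higher number (0.72 log units; beyond the scatter) from compound 1 to compound 2 and a 3.8-fold higher number (0.58 log units; beyond the scatter) from compound 3 to compound 4, 1.4-fold (0.14 log units) apart, within the scatter of two such steps. This shows that, in these two pairs, the change carried from one core to the other in direction and in a size that agrees within the scatter, but it does not show a rule for the whole series, and since the earlier pair reads 4-methylphenyl to 4-chlorophenyl, the two steps also differ in which group carries the change.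

The compounds shown leave open whether a methoxy group, a trifluoromethyl group or an amine in that place would move the number the same way. They also leave open whether the step would hold with the same change made on both aromatic groups of one core.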